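From compound 2 to compound 3 at the assay limit

This account rests on a few compounds, and the source may have more. Where it says the series, first, only, none or still open, it means among the compounds named here.

Measured so far in a functional assay on BT-549 cells (Homo sapiens) for inhibition, read by sulforhodamine B assay, with a stated time of 48 h (on this read-out lower numbers stand for stronger inhibition of growth and higher numbers for weaker inhibition of growth), are two compounds:
compound 1 `Cc1ccc(C2=NN(c3ccc(S(C)(=O)=O)cc3)C(=O)CC2)cc1` gives > 100000 nM as a limit
compound 2 `Cc1cc(O)ccc1C1=NN(c2ccc(S(C)(=O)=O)cc2)C(=O)CC1` gives > 100000 nM as a limit

Compound 2 therefore stands at > 100000 nM as a limit and not as a number. Both compounds sit at the limit of > 100000 nM in this assay, at which 2 of the 2 values shown sit, and no actual number has yet been read. Compound 3 `CCc1ccc(C2=NN(c3ccc(S(C)(=O)=O)cc3)C(=O)CC2)cc1` carries 4-ethylphenyl in place of 4-hydroxy-2-methylphenyl on a carbon with a double bond to nitrogen. Among the measured compounds shown here, the only measured step at this place is a step that the two limits leave unreadable from compound 1 to compound 2 and it offers no size to carry over, so no readable step is expected in this assay and compound 3 is expected to sit at the same limit. The estimated outcome is a number no higher from compound 2 to compound 3 (the limit leaves the size open) with no direction favoured. The estimate for compound 3 is 100000 nM with an expected range from 50000 nM to 200000 nM and a good chance that the outcome is only a limit.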

Compound 3, concentration for total growth inhibition: 35600 nM
Compound 3: the middle estimate sits 2.8-fold (0.45 log units) above what was measured; measured number outside the range, below it.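

In this assay compound 3 gives 35600 nM, which shows that this place on a carbon with a double bond to nitrogen can hold a group that brings growth inhibition into the readable range. A small extension of the chain is enough for this: methyl in place of hydrogen on a saturated chain carbon bound to an aromatic carbon gives an at least 2.8-fold lower number from compound 1 to compound 3 (0.44 log units; beyond the scatter), and the exchange of the 4-hydroxy-2-methylphenyl group for 4-ethylphenyl gives an at least 2.8-fold lower number from compound 2 to compound 3 (0.44 log units; beyond the scatter). Compound 3 is thus the only compound shown with an actual number rather than a limit: the limit of > 100000 nM in this assay, at which 2 of the 3 values shown sit.

Going by these compounds, the step from compound 1 to compound 2 cannot be read, so what the hydroxy and the added methyl of the 4-hydroxy-2-methylphenyl group contribute remains open, as does the true size of both readable steps. On these data alone, it also remains open whether a longer chain such as propyl, or an amine in place of the ethyl, would move the number further in this assay.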